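Replacing a bromophenyl ketone with a furyl ketone

The source may hold more compounds than are shown below. What is called first, only, known or untested is meant among the compounds shown, and "the series" means these compounds.

Measured so far:
- compound 1, `COc1cc(-c2nnc3n2NC(c2ccco2)C(C(=O)c2ccccc2F)S3)cc(OC)c1OC`: 78700 nM
- compound 2, `COc1cc(-c2nnc3n2NC(c2ccco2)C(C(=O)c2cccc(Br)c2)S3)cc(OC)c1OC`: 36900 nM

In a functional assay on A549 cells (Homo sapiens) for cytotoxicity, read by MTT assay, with a stated time of 48 h (a higher number here means a weaker inhibitor, a lower number a stronger inhibitor), compound 2 gives 36900 nM, the lowest of the two numbers, and the nearest measured point is compound 1 with 78700 nM. For the measured compounds named here, the one step measured here, a 2.1-fold lower number from compound 1 to compound 2 (0.33 log units; beyond the scatter), swaps one aromatic group for another on the carbonyl carbon. Compound 3, `COc1cc(-c2nnc3n2NC(c2ccco2)C(C(=O)c2ccco2)S3)cc(OC)c1OC`, changes that same position again: furan-2-yl in place of 3-bromophenyl on a carbonyl carbon. Going by the values given here, no measured step shows what a furan-2-yl on this carbonyl does, so the only guide is that a swap at this position moved the number modestly. The step from compound 2 to compound 3 is therefore expected to be small, in either direction or none beyond the scatter, as a 1.4-fold higher number from compound 2 to compound 3 (0.13 log units; within the scatter). Compound 3 is estimated at 50000 nM, with a range from 18000 nM to 130000 nM.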

Compound 3, half-maximal inhibitory concentration: 68700 nM
Compound 3: the middle estimate sits 1.4-fold (0.14 log units) below what was measured; the range from low to high includes it.
By their numbers in this assay, from the lowest: compounds 2, 3 and 1 (each within the scatter of the next, the first and the last beyond it).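

In this assay, furan-2-yl brings a five-membered ring with an oxygen to this carbonyl carbon, yet neither comparison with the phenyl-bearing compounds can be told apart from repeat-measurement noise: a 1.9-fold higher number from compound 2 to compound 3 (0.27 log units; within the scatter) and a 1.1-fold lower number from compound 1 to compound 3 (0.06 log units; within the scatter). Swapping either substituted phenyl for this smaller ring therefore gives no step beyond the scatter, and a 2.1-fold lower number from compound 1 to compound 2 (0.33 log units; beyond the scatter) remains the only step here that exceeds it. No measurement shown offers a reason for these numbers.

The compounds shown leave open whether a different kind of group on this carbonyl carbon, such as a carboxylic acid or a simple amine, would move the number further than these aromatic swaps. They also leave open whether changes elsewhere on the shared core would produce larger steps.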